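Chloro on the Shared Core: What to Expect for Compound 4

This account rests on a few compounds, and the source may have more. Where it says the series, first, only, none or still open, it means among the compounds named here.

Measured so far:
- Compound 1, `COc1ccc(S(=O)(=O)Nc2cccc3cc[nH]c23)cc1`: in a functional assay on MC-38 cells (Mus musculus) for antiproliferative activity, read by colorimetric assay and MTT assay (a higher number here means a weaker inhibitor, a lower number a stronger inhibitor), compound 1 gives 1.5 ug/mL.
- Compound 2, `COc1ccc(S(=O)(=O)Nc2ccc(Cl)c3cc[nH]c23)cc1`: compound 2 gives 0.65 ug/mL.
- Compound 3, `Nc1ccc(S(=O)(=O)Nc2cccc3cc[nH]c23)cc1`: compound 3 gives 6.1 ug/mL.

The three measured compounds share one sulfonamide scaffold. Compound 2 differs from compound 1 by chloro in place of hydrogen on an aromatic carbon, and that change gave a 2.3-fold lower number from compound 1 to compound 2 (0.36 log units; beyond the scatter). Compound 3 differs from compound 1 by amino in place of methoxy on an aromatic carbon, and that change went the other way, giving a 4.1-fold higher number from compound 1 to compound 3 (0.61 log units; beyond the scatter), so compound 3 has the highest number of the three.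

Compound 4, `Nc1ccc(S(=O)(=O)Nc2cccc3cc(Cl)[nH]c23)cc1`, is not yet measured. It differs from compound 3 by chloro in place of hydrogen on an aromatic carbon. Among the compounds with values here, this is the same kind of change as the one from compound 1 to compound 2, but not the same change: there the chloro entered on a six-membered aromatic ring of carbon only, ortho to a fused ring, meta to a fused ring and para to a large group, whereas here it enters on a five-membered aromatic ring with one nitrogen, next to the ring nitrogen. The two cores also differ, as described above through (amino in place of methoxy on an aromatic carbon). Within the data shown here, with only one earlier example of a chloro step, and that one at a different place, the expectation for compound 4 is cautious: a step of a 1.7-fold lower number from compound 3 to compound 4 (0.24 log units; within the scatter) is expected, resting on the step of a 2.3-fold lower number from compound 1 to compound 2 (0.36 log units; beyond the scatter) seen before. Compound 4 is therefore estimated at 3.5 ug/mL in this assay, with a range from 1.5 ug/mL to 8 ug/mL.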

Compound 4, half-maximal inhibitory concentration: 2.9 ug/mL
Compound 4: middle estimate off by 1.2-fold (0.08 log units), on the high side; low and high end bracket the measured number.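

In this assay, putting chloro on the core of compound 3 gives a 2.1-fold lower number from compound 3 to compound 4 (0.32 log units; beyond the scatter), and this step matches the earlier chloro step in size: the same change on two cores in this assay, a 2.3-fold lower number (0.36 log units; beyond the scatter) from compound 1 to compound 2 and a 2.1-fold lower number (0.32 log units; beyond the scatter) from compound 3 to compound 4, 1.1-fold (0.04 log units) apart, within the scatter of two such steps In these two pairs, then, the lower number that came with a chloro on the methoxy core also appeared on the amino core, and by a similar amount. Within the data shown here, this does not show that the change carries over in general, since there are only two examples and the chloro does not occupy the same place in both: in compound 4 it sits on the five-membered aromatic ring, next to the ring nitrogen, while in compound 2 it sits elsewhere on the shared core, so the effects of place and core cannot be separated, and the matching sizes say nothing about why the number falls.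

The compounds shown leave open what a chloro would do at the place it holds in compound 2 on the amino core, or at the place it holds in compound 4 on the methoxy core. They also leave open whether another group at these places, such as fluoro, bromo or methyl, would lower the number as chloro does.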